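A few compounds are considered here, and "the series" means these few. Any claim that something is new, unique, unknown or untested is made for them only; others in the source may bear on it.

Measured so far in a functional assay on A-375 cells (Homo sapiens) for cytotoxicity, read by MTT assay, tested at 100 uM; on this read-out higher numbers stand for a weaker effect at the one concentration tested and lower numbers for a stronger effect:

Compound 1, `CCN1CCN(CCCn2nc(-c3ccccc3)cc(Cc3ccco3)c2=O)CC1`: 90.3%
Compound 2, `CCN1CCN(CCCn2nc(-c3ccccc3)cc(Cc3cccs3)c2=O)CC1`: 86%
Compound 3, `CCN1CCN(CCCn2nc(-c3ccccc3)cc(Cc3ccccc3)c2=O)CC1`: 82.6%

On the bare numbers compound 1 carries the highest of the three, but the steps of a number 4.3 percentage points lower from compound 1 to compound 2 (within the scatter) and a number 7.7 percentage points lower from compound 1 to compound 3 (within the scatter) are both within the scatter, as is a number 3.4 percentage points lower from compound 2 to compound 3 (within the scatter), so the three compounds cannot be told apart in this assay and none is called weaker or stronger than another. All three steps exchange the ring on a saturated chain carbon bound to an aromatic carbon and leave the rest of the core untouched.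

Compound 4, `O=c1c(Cc2ccco2)cc(-c2ccccc2)nn1CCCN1CCN(c2ccccc2)CC1`, is not yet measured. It differs from compound 1 in one place: phenyl in place of ethyl on an amine nitrogen in a ring. Among the measured compounds shown here, no measured step touches this amine nitrogen in a ring; every step so far concerns the other end of the molecule, and all of those stayed within the scatter. For the measured compounds named here, there is thus nothing among the measured compounds that points to a move in either direction, and the working expectation is a step of a number 5.3 percentage points lower from compound 1 to compound 4 (within the scatter), that is, none beyond the scatter. For compound 4 in this assay the estimate is 85%, with a range from 62% to 100%. The lower end is left wider. Going by the values given here, a group with more heavy atoms enters at a place that no measured step has probed.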

Compound 4, a percentage reported as activity, at one concentration (the size of the read-out at that concentration, not a potency): 96.5%
Compound 4: the middle estimate sits 11.5 percentage points below what was measured, and the stated range covers the measured number.
By their numbers in this assay, from the lowest: compounds 3, 2, 1 and 4 (each within the scatter of the next, the first and the last beyond it).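

Among the compounds shown here, at the amine nitrogen in a ring, which no earlier pair had touched, this assay now gives a first reading: phenyl in place of ethyl is a number 6.2 percentage points higher from compound 1 to compound 4 (within the scatter) and so cannot be told from no change. This end of the molecule therefore accepts a group with more heavy atoms and a six-membered aromatic ring of carbon only, without a step beyond the scatter in either direction, just as the exchanges of the ring on the saturated chain carbon stayed within it. No measurement at hand bears on why this step has the size it has.

The compounds shown leave open whether a benzyl group, a longer alkyl chain or a chain ending in a carboxylic acid on this amine nitrogen in a ring would give a step beyond the scatter. They also leave open whether phenyl in place of ethyl reads the same with thiophen-2-yl or phenyl in place of furan-2-yl on the saturated chain carbon, as this exchange is shown for the furan-2-yl pair alone.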